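The source may hold more compounds than are shown below. What is called first, only, known or untested is meant among the compounds shown, and "the series" means these compounds.

Measured compounds:
compound 1 `COc1cc(OC)c(C(=O)/C=C/c2ccccc2Cl)c(O)c1CN1CCCC1`: 6900 nM
compound 2 `COc1cc(OC)c(C(=O)/C=C/c2ccccc2Cl)c(O)c1CN(C)CC(=O)O`: 44400 nM

In a functional assay on ECa-109 cells (Homo sapiens) for antiproliferative activity, with a stated time of 72 h (a lower number here means a stronger inhibitor, a higher number a weaker inhibitor), compound 1 holds the lowest of the two numbers; the step from it to compound 2 is a 6.4-fold higher number from compound 1 to compound 2 (0.81 log units; beyond the scatter), a change of the group on a saturated chain carbon bound to an aromatic carbon. Compound 3 `CCN(C)Cc1c(OC)cc(OC)c(C(=O)/C=C/c2ccccc2Cl)c1O` differs from compound 1 by ethyl(methyl)amino in place of pyrrolidin-1-yl on a saturated chain carbon bound to an aromatic carbon. Going by the values given here, the only measured step at this position is a 6.4-fold higher number from compound 1 to compound 2 (0.81 log units; beyond the scatter), which involves a different entering group, so it bears on compound 3 only loosely. The change to compound 3 is expected to be small, estimated at a 1.3-fold higher number from compound 1 to compound 3 (0.12 log units; within the scatter) in this assay. Compound 3 is expected to give 9000 nM, within 3500 nM to 25000 nM.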

Compound 3, half-maximal inhibitory concentration: 1400 nM
Estimate against measurement, compound 3: 6.4-fold (0.81 log units) above; measured number below the stated range.
By their numbers in this assay, from the lowest: compound 3; then compound 1; then compound 2.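

With ethyl(methyl)amino in place of pyrrolidin-1-yl on a saturated chain carbon bound to an aromatic carbon, this assay shows a 4.9-fold lower number from compound 1 to compound 3 (0.69 log units; beyond the scatter) at this position, so the number here can fall as well as rise, and a ring is not required for the lower value. Methyl in place of carboxy gives a 32-fold lower number from compound 2 to compound 3 (1.50 log units; beyond the scatter) and is the largest step in this small set. No evidence on hand accounts for either step.

The compounds shown leave open whether the lower number holds for other open-chain amines, such as diethylamino. On these data alone, how a ring amine such as morpholin-4-yl would read at this place also remains open.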